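This account rests on a few compounds, and the source may have more. Where it says the series, first, only, none or still open, it means among the compounds named here.

Measured compounds in a functional assay on the whole organism (strain Kunming) with Mus musculus as the target; a higher number here means that more compound is needed for the effect, a lower number that less compound is needed:

Compound 1 `O=C1CC(c2cccc(Cl)c2)n2ncnc2N1` gives 47.3 mg/kg.
Compound 2 `O=C1CC(c2cccc(Br)c2)n2ncnc2N1` gives 84.9 mg/kg.

Compound 2 stands alongside compound 1 in this assay: the step of a 1.8-fold higher number from compound 1 to compound 2 (0.25 log units; within the scatter) does not separate the two compounds, so the two numbers say the same thing about the effect of a single halogen at this position of the ring.

Compound 3 `O=C1CC(c2cccc(C(F)(F)F)c2)n2ncnc2N1` has not yet been measured. Its structural change from compound 2 is trifluoromethyl in place of bromo on an aromatic carbon. Among the compounds with values here, the only measured step that bears on it is the one from compound 1 to compound 2, where one halogen replaced another at the same place, and that step stayed within the scatter. Within the data shown here, no measured step shows a halogen giving way to a trifluoromethyl group, so there is nothing in the data that points in either direction. The step from compound 2 to compound 3 in this assay is therefore expected to be a 1.2-fold lower number from compound 2 to compound 3 (0.08 log units; within the scatter), a change that would not exceed the scatter. Compound 3 is estimated to give 70 mg/kg, with a range from 30 mg/kg to 160 mg/kg.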

Compound 3, dose for half-maximal effect: 54.8 mg/kg
Compound 3: the middle estimate sits 1.3-fold (0.11 log units) above what was measured; low and high end bracket the measured number.
By their numbers in this assay, from the lowest: compounds 1, 3 and 2 (each within the scatter of the next).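

In this assay, trifluoromethyl brings four heavy atoms to the place where bromo brought one, yet the result is only a 1.5-fold lower number from compound 2 to compound 3 (0.19 log units; within the scatter), and the comparison with the chloro compound gives a 1.2-fold higher number from compound 1 to compound 3 (0.06 log units; within the scatter). The earlier compounds shown here showed only that one halogen could replace another on this aromatic carbon, meta to a large group, without separating the two numbers; now a group of several atoms, and not a halogen atom, also gives a number that cannot be told apart from theirs. Nothing available explains why these three groups give such similar numbers.

From the compounds shown here alone, what a plain hydrogen on this carbon would give remains open, and with it whether any of these groups is needed here at all. Going by these compounds, it is also open whether an amine or a carboxylic acid in the same place would keep the number close to those of these three compounds.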